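The compounds below may be only part of what the source reports. "The series", "measured", "known", "first", "only" and "open" are said of these compounds alone.

In a functional assay on MCF7 cells (Homo sapiens) for inhibition, read by MTT assay, with a stated time of 48 h, tested at 10 uM (a higher number here means more inhibition of growth at the concentration tested, a lower number less inhibition of growth), compound 1 (`Cc1cc(=O)c2c(O)c(CN3CCC(N4CCCCC4)CC3)c(O)c([C@H]3CCN(C)C[C@H]3O)c2o1`) gives 25%, compound 2 (`Cc1oc2c([C@H]3CCN(C)C[C@H]3O)c(O)cc(O)c2c(=O)c1C(O)c1ccccc1Br`) gives 21% and compound 3 (`Cc1oc2c([C@H]3CCN(C)C[C@H]3O)c(O)cc(O)c2c(=O)c1C(O)c1c(Cl)cccc1Cl`) gives 33%. Compound 3 has the highest of these numbers, but its gap to compound 1 lies within the scatter, and only its gap to compound 2 lies beyond it.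

The next compound is compound 4 (`Cc1oc2c([C@H]3CCN(C)C[C@H]3O)c(O)cc(O)c2c(=O)c1C(O)c1ccc(F)cc1`), with this change from compound 3: 4-fluorophenyl in place of 2,6-dichlorophenyl on a saturated chain carbon bound to an aromatic carbon and an oxygen on a saturated carbon. Here, 4-fluorophenyl stands in place of 2,6-dichlorophenyl on a saturated chain carbon bound to an aromatic carbon and an oxygen on a saturated carbon.

Among the measured compounds shown here, one measured step bears on this place: a number 12 percentage points higher from compound 2 to compound 3 (beyond the scatter). It is modest and brought 2,6-dichlorophenyl in, whereas the new change takes that group out. For the measured compounds named here, no measured compound carries 4-fluorophenyl, so the guidance is thin. A small fall in this assay is therefore expected, no larger than that modest step.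

The expected change is a number 8 percentage points lower from compound 3 to compound 4 (within the scatter).

For compound 4, the estimated value is 25%, with an expected range of 12% to 38%.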

Compound 4, percent growth inhibition at one concentration: 9%
Compound 4: middle estimate off by 16 percentage points, on the high side; the measured number lies below the stated range.
By their numbers in this assay, from the lowest: compound 4; then compounds 2, 1 and 3 (each within the scatter of the next, the first and the last beyond it).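

In this assay, the aryl group on this saturated chain carbon now has a third member, and 4-fluorophenyl in place of 2,6-dichlorophenyl gives a number 24 percentage points lower from compound 3 to compound 4 (beyond the scatter). Set against 2-bromophenyl, the same group gives a number 12 percentage points lower from compound 2 to compound 4 (beyond the scatter), so compound 4 lies beyond the scatter below both other aryl compounds, and all three steps among these aryl groups exceed the scatter, showing that this position responds to the choice of aryl group more clearly than a single step could show. No supporting data explain these differences.

The halogen and its placement change together across these three aryl groups, so their separate contributions remain unresolved. Plain phenyl, 4-chlorophenyl and 2,6-difluorophenyl would separate them, and how an amine in place of the hydroxy on the same carbon would read also remains open.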